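Second chloro on the aryl of the weakest thiosemicarbazide

A few compounds are considered here, and "the series" means these few. Any claim that something is new, unique, unknown or untested is made for them only; others in the source may bear on it.

Measured so far:
compound 1, `Fc1ccc(C2=NN(C(=S)Nc3ccccc3)C(c3ccc4c(c3)OCCO4)C2)cc1`, 15700 nM
compound 2, `S=C(Nc1ccccc1)N1N=C(c2ccc(Cl)cc2)CC1c1ccc2c(c1)OCCO2`, 195000 nM
compound 3, `COc1cccc(C2=NN(C(=S)Nc3ccccc3)C(c3ccc4c(c3)OCCO4)C2)c1`, 520 nM

In a functional assay on A-375 cells (Homo sapiens) for antiproliferative activity, read by MTT assay, with a stated time of 48 h (on this read-out higher numbers stand for weaker inhibition of growth and lower numbers for stronger inhibition of growth), compound 2 gives the highest of the three numbers. The nearest is compound 1, reached by the step of a 12-fold higher number from compound 1 to compound 2 (1.09 log units; beyond the scatter); compound 3 lies furthest away, as the step of a 380-fold lower number from compound 2 to compound 3 (2.57 log units; beyond the scatter) shows. Compound 4, `S=C(Nc1ccccc1)N1N=C(c2ccc(Cl)c(Cl)c2)CC1c1ccc2c(c1)OCCO2`, differs from compound 2 by one change: chloro in place of hydrogen on an aromatic carbon.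

For the measured compounds named here, no measured step adds a chloro group to an aryl that already carries one. Going by the values given here, the only halogen step known is a 12-fold higher number from compound 1 to compound 2 (1.09 log units; beyond the scatter), which went the wrong way; the large drop a 30-fold lower number from compound 1 to compound 3 (1.48 log units; beyond the scatter) belongs to a different group and does not transfer. With nothing to anchor the direction, the expected step of a 1.6-fold lower number from compound 2 to compound 4 (0.21 log units; within the scatter) is small, and a change within the scatter is as likely as not. For compound 4 the estimate is therefore 120000 nM, with a wide range of 30000 nM to 400000 nM.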

Compound 4, concentration for 50% growth inhibition: 41900 nM
Compound 4: middle estimate off by 2.9-fold (0.46 log units), on the high side, and the stated range covers the measured number.
By their numbers in this assay, from the lowest: compound 3; then compound 1; then compound 4; then compound 2.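

In this assay, for the compounds shown here, a second chloro group on the aryl of compound 2 gives the first measured step that adds a halogen and lowers the number (a 4.7-fold lower number from compound 2 to compound 4 (0.67 log units; beyond the scatter)), so a chloro group ortho to a chloro group is tolerated better than the 4-chlorophenyl alone. This recovery is partial: 3,4-dichlorophenyl still stands behind 4-fluorophenyl (a 2.7-fold higher number from compound 1 to compound 4 (0.43 log units; beyond the scatter)) and far behind 3-methoxyphenyl (an 81-fold higher number from compound 3 to compound 4 (1.91 log units; beyond the scatter)). No evidence on the cause of these shifts is available here.

On these data alone, what an amine or a carboxylic acid would give at this place on the aryl stays open. Also open, as far as these compounds go, is whether a chloro group added in the same place would lower the number on the 4-fluorophenyl of compound 1 as well.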